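The compounds below may be only part of what the source reports. "The series", "measured", "known", "first", "only" and "open" are said of these compounds alone.

Measured so far:
compound 1 `CC(=O)N[C@H]1[C@H]([C@@H](O)[C@H](O)CNC(=O)c2ccc(Cl)cc2)O[C@@](OCc2ccccc2)(C(=O)O)C[C@@H]1O` — 17000 nM
compound 2 `CC(=O)N[C@H]1[C@H]([C@@H](O)[C@H](O)CNC(=O)c2ccc(Cl)c(Cl)c2)O[C@@](OCc2ccccc2)(C(=O)O)C[C@@H]1O` — 19200 nM

In an in vitro assay on cells for binding affinity to myelin-associated glycoprotein (Mus musculus), read by surface plasmon resonance (on this read-out lower numbers stand for tighter binding and higher numbers for weaker binding), compound 2 holds the highest of the two numbers, and its nearest neighbour is compound 1, with a 1.1-fold higher number from compound 1 to compound 2 (0.05 log units; within the scatter). Compound 3 `CC(=O)N[C@H]1[C@H]([C@@H](O)[C@H](O)CNC(=O)c2cccc(Cl)c2)O[C@@](OCc2ccccc2)(C(=O)O)C[C@@H]1O` differs from compound 2 by hydrogen in place of chloro on an aromatic carbon. Within the data shown here, only one measured step bears on this change: adding a chloro to the same ring gave a 1.1-fold higher number from compound 1 to compound 2 (0.05 log units; within the scatter), a step that stayed within the scatter. Taking a chloro off that ring, at a different place, is therefore expected to move the number little, if at all, in this assay. For compound 3 the estimated step is a 1.1-fold lower number from compound 2 to compound 3 (0.03 log units; within the scatter), with no direction claimed beyond the scatter. Compound 3 is thus expected to give about 18000 nM, in a range from 9000 nM to 38000 nM.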

Compound 3, dissociation constant: 33900 nM
Beside the measured number, compound 3's estimate is 1.9-fold (0.27 log units) below it; the measured number falls inside the stated range.
By their numbers in this assay, from the lowest: compounds 1, 2 and 3 (each within the scatter of the next).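

In this assay, removing one chloro so that 3,4-dichlorophenyl becomes 3-chlorophenyl gives a 1.8-fold higher number from compound 2 to compound 3 (0.25 log units; within the scatter), and placing the single chloro as 3-chlorophenyl instead of 4-chlorophenyl gives a 2.0-fold higher number from compound 1 to compound 3 (0.30 log units; within the scatter). Both steps stay within the scatter, so neither the loss of this chloro nor the shift of the chloro on the ring can be read as a real change in binding, and the chloro at this place has now shown no readable effect whether added or taken away. Nothing measured here offers an explanation for these numbers.

Still open, as far as these compounds go, is whether a different group at this place, such as an amine, a methoxy group or a carboxylic acid, would move the number beyond the scatter. Also open, from the compounds shown here alone, is how a phenyl ring carrying no chloro at all would compare.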